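The source may report more compounds than this note shows. Statements on the series, on what has been measured and on what is new or still open speak of the compounds shown alone.

Working notes on the series. Among the compounds with values here, in an ADME assay on liver for metabolic stability, with Liver microsome (Rattus norvegicus) as the target, using microsomes and NADPH, with a stated time of 30 min, tested at 0.5 uM (on this read-out higher numbers stand for fast clearance and lower numbers for slow clearance), compound 3 `O=C1NCCN1CCOc1nn(-c2ccccc2F)c2ccc(F)cc12` gives 1380 mL/min/kg, the second highest of the three numbers so far. Compound 1 `CN1CCN(CCOc2nn(-c3ccccc3F)c3ccc(F)cc23)C1=O` gives 7200 mL/min/kg and compound 2 `O=C(COc1nn(-c2ccccc2F)c2ccc(F)cc12)N1CCOCC1` gives 183 mL/min/kg; the steps among these three are a 5.2-fold lower number from compound 1 to compound 3 (0.72 log units; beyond the scatter), a 7.5-fold higher number from compound 2 to compound 3 (0.88 log units; beyond the scatter) and a 39-fold lower number from compound 1 to compound 2 (1.59 log units; beyond the scatter). Compound 4 `O=C1NCCN1CCOc1nn(-c2ccc(F)cc2)c2ccc(F)cc12` differs from compound 3 only in this: 4-fluorophenyl in place of 2-fluorophenyl on an aromatic nitrogen. Within the data shown here, none of the measured steps touches the group on the aromatic nitrogen; all three concern the group on the saturated chain carbon bound to the oxygen, so no measured step bears on this change and no shift beyond the scatter is expected. The estimate for compound 4 is 1400 mL/min/kg (range 500 mL/min/kg to 4000 mL/min/kg), meaning an expected step of a 1.0-fold higher number from compound 3 to compound 4 (0.01 log units; within the scatter).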

Compound 4, clearance: 217 mL/min/kg
Compound 4: middle estimate off by 6.5-fold (0.81 log units), on the high side, and the stated range ends above it.
By their numbers in this assay, from the lowest: compounds 2 and 4 (each within the scatter of the next); then compound 3; then compound 1.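

The group on the aromatic nitrogen matters in this assay: 4-fluorophenyl in place of 2-fluorophenyl gives a 6.4-fold lower number from compound 3 to compound 4 (0.80 log units; beyond the scatter) even though both groups have the same atoms. Within the data shown here, this is the first measured step at this position, since the earlier steps all concern the group on the saturated chain carbon bound to the oxygen. Nothing available bears on why the number shifts.

From the compounds shown here alone, whether the same change carries over to the side chains of compound 1 and compound 2 stays open. So does the outcome with a plain phenyl or a pyridyl group on that nitrogen.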